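Swapping an aromatic ring for a hexyl chain

A few compounds are considered here, and "the series" means these few. Any claim that something is new, unique, unknown or untested is made for them only; others in the source may bear on it.

In an assay on cells for agonist activity at ecdysone receptor (Bombyx mori), read by a luciferase reporter, with a stated time of 24 h (on this read-out lower numbers stand for an effect already at smaller amounts and higher numbers for an effect only at larger amounts of compound), three compounds have been measured:
compound 1 `CC(C)(C)N(NC(=O)c1ccccc1)C(=O)c1ccccc1C(F)(F)F`: 631 nM
compound 2 `Cc1ccccc1C(=O)N(NC(=O)c1ccccc1)C(C)(C)C`: 224 nM
compound 3 `CC(C)(C)N(NC(=O)c1ccccc1Br)C(=O)c1ccccc1Cl`: 316 nM

Compound 2 stands at the lowest number of the three; compound 3 lies within the scatter of it, while compound 1 lies beyond it, shown by a 2.8-fold lower number from compound 1 to compound 2 (0.45 log units; beyond the scatter). Compound 4 `CCCCCCC(=O)N(NC(=O)c1ccccc1)C(C)(C)C` differs from compound 2 by hexyl in place of 2-methylphenyl on a carbonyl carbon. Within the data shown here, no measured step bears on this change: the only step compares two groups on an aromatic ring, and compound 3 differs from compound 2 in two places, so only its value can be set beside that of compound 2. The expectation thus rests on the change itself. Compound 4 is expected to give a clearly higher number, estimated at 3000 nM with a range of 500 nM to 20000 nM. The expected step is a 13-fold higher number from compound 2 to compound 4 (1.13 log units; beyond the scatter).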

Compound 4, half-maximal effective concentration: 7240 nM
Estimate against measurement, compound 4: 2.4-fold (0.38 log units) below; the range from low to high includes it.
By their numbers in this assay, from the lowest: compounds 2, 3 and 1 (each within the scatter of the next, the first and the last beyond it); then compound 4.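

The earlier compounds shown here only changed groups on an aromatic ring, whereas here the ring on the carbonyl carbon is itself replaced, and in this assay hexyl in place of 2-methylphenyl gives a 32-fold higher number from compound 2 to compound 4 (1.51 log units; beyond the scatter). So this position tolerates the swap poorly, even though neither group has a hydrogen-bond donor, a hydrogen-bond acceptor or a net charge. Nothing measured here explains the size of this step. Still open, going by these compounds, is whether a cyclohexyl ring or a shorter butyl chain on this carbonyl carbon would stay closer to compound 2 or to compound 4.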